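Fluoro on the carboxyphenyl group of compound 2

The source may hold more compounds than are shown below. What is called first, only, known or untested is meant among the compounds shown, and "the series" means these compounds.

In an ADME assay on a cell-free system (plasma, Rattus norvegicus) for metabolic stability, read by LC-MS, with a stated time of 60 min, tested at 100 uM (on this read-out higher numbers stand for a more stable compound and lower numbers for a less stable compound), compound 1 (`Cc1c(OCCCCOc2ccc(C(=O)O)cc2Cl)ccc(C(=O)CC(C)C)c1O`) gives 123% as its reading. Compound 2 (`Cc1c(OCCCCOc2cccc(C(=O)O)c2)ccc(C(=O)CC(C)C)c1O`) gives 100% and holds the lower of the two numbers. Going by the values given here, the only measured step is a number 23 percentage points lower from compound 1 to compound 2 (beyond the scatter) and it brings in no fluoro group, so it offers only a loose guide to size. Compound 3 (`Cc1c(OCCCCOc2ccc(F)c(C(=O)O)c2)ccc(C(=O)CC(C)C)c1O`) differs from compound 2 by fluoro in place of hydrogen on an aromatic carbon, ortho to a carboxy group and para to a large group (fluoro in place of hydrogen on an aromatic carbon). Among the compounds with values here, no measured step isolates this change. With compound 2 at 100% as the anchor, no move beyond the scatter is expected. The estimated move is a number 3 percentage points higher from compound 2 to compound 3 (within the scatter) in this assay on present data. Compound 3 is expected at 103% with an estimated range of 86% to 120% for now.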

Compound 3, percent of the compound remaining: 101%
Compound 3: the middle estimate sits 2 percentage points above what was measured, within the range that was stated.
By their numbers in this assay, from the lowest: compounds 2 and 3 (each within the scatter of the next); then compound 1.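

Fluoro on an aromatic carbon, ortho to a carboxy group and para to a large group, gives no reading distinct from hydrogen in this assay: the result is a number 1 percentage points higher from compound 2 to compound 3 (within the scatter). The 3-carboxy-4-fluorophenyl group also leaves the gap to the 4-carboxy-2-chlorophenyl group in place, with a number 22 percentage points lower from compound 1 to compound 3 (beyond the scatter), so adding fluoro at this position does not recover the higher reading of compound 1. Nothing available gives a reason for either step.

As far as these compounds go, whether a larger group at this position, such as methoxy or trifluoromethyl, would also stay within the scatter remains open. The compounds shown also do not separate the contribution of the chloro group from that of the carboxy group's position in compound 1.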